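Thiocarbamate in Place of a Fluorinated Cyclobutyl Carbamate

A few compounds are considered here, and "the series" means these few. Any claim that something is new, unique, unknown or untested is made for them only; others in the source may bear on it.

Compound 2 `Cc1nc(S(C)(=O)=O)ccc1Oc1ncnc(OC2CCN(C(=O)OC3(C(F)(F)F)CCC3)CC2)c1F` gives the lower of the two numbers recorded in a functional assay on isolated protein for inhibition of Glucose-dependent insulinotropic receptor (Rattus norvegicus), read by HTRF and cAMP accumulation; on this read-out higher numbers stand for an effect only at larger amounts of compound and lower numbers for an effect already at smaller amounts. In this assay, within the data shown here, compound 2 gives 63.3 nM, whereas compound 1 `Cc1nc(S(C)(=O)=O)ccc1Oc1ncnc(OC2CCN(C(=O)OC3CCC3)CC2)c1F` gives 167 nM; the only measured step, a 2.6-fold lower number from compound 1 to compound 2 (0.42 log units; beyond the scatter), put a trifluoromethyl in place of hydrogen on a saturated ring carbon. Compound 3 `Cc1nc(S(C)(=O)=O)ccc1Oc1ncnc(OC2CCN(C(=O)SC(C)C)CC2)c1F` changes a different part of the molecule: a group of 4 heavy atoms (3 carbon, 1 sulfur; no ring) in place of a group of 9 heavy atoms (5 carbon, 1 oxygen, 3 fluorine; one four-membered non-aromatic ring of carbon only), on a carbonyl carbon. Among the measured compounds shown here, no measured step mirrors this exchange, so the step from compound 1 to compound 2 bears on it only in showing that the trifluoromethyl contributed a modest gain that is now removed together with the four-membered ring. Compound 3 is therefore expected to land near compound 1 or somewhat weaker, with the step of a 3.5-fold higher number from compound 2 to compound 3 (0.54 log units; beyond the scatter) estimated in the direction of a higher number. The estimate for compound 3 in this assay is 220 nM, with a range from 70 nM to 700 nM.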

Compound 3, half-maximal effective concentration: 41.3 nM
Compound 3: middle estimate off by 5.3-fold (0.73 log units), on the high side; the measured number lies below the stated range.
By their numbers in this assay, from the lowest: compounds 3 and 2 (each within the scatter of the next); then compound 1.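

In this assay, the step to isopropylsulfanyl on the carbonyl carbon, a 1.5-fold lower number from compound 2 to compound 3 (0.19 log units; within the scatter), shows that this place can hold a much smaller group with no ring and no fluorine while the number stays within the scatter of that of compound 2. Set against the cyclobutyloxy group, the same isopropylsulfanyl group gives a 4.0-fold lower number from compound 1 to compound 3 (0.61 log units; beyond the scatter), so a trifluoromethyl on the four-membered ring is not the only change at this carbonyl carbon that moves the number beyond the scatter from that of compound 1. Nothing available explains either step.

On these data alone, what an isopropyloxy or a cyclobutylsulfanyl group would give here stays open, and with it whether the sulfur or the open-chain isopropyl part goes with the lower number. As far as these compounds go, an isopropylamino group on the same carbonyl carbon is equally open.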